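The source may report more compounds than this note shows. Statements on the series, on what has been measured and on what is new or still open speak of the compounds shown alone.

Compound 1 `Nc1n[nH]c2cc(-c3ccc(=O)n(Cc4ccccc4)c3)ccc12` gives 32 nM in an assay for inhibition of MAP kinase-interacting serine/threonine-protein kinase 2 (Homo sapiens), read by luminescence and ADP-Glo, with a stated time of 2 h; a higher number here means a weaker inhibitor, a lower number a stronger inhibitor. Compound 2 `NC(=O)c1ccc(Cn2cc(-c3ccc4cn[nH]c4c3)ccc2=O)cc1` returns only a limit of this assay, > 2000 nM, as noted for (the limit of > 2000 nM in this assay, at which 1 of the 3 values shown sits). Among the compounds with values here, compound 3 `CC(=O)Nc1cccc(Cn2cc(-c3ccc4c(N)n[nH]c4c3)ccc2=O)c1` gives 8 nM in this assay, the lowest of the two numbers available, and the single measured step, a 4.0-fold lower number from compound 1 to compound 3 (0.60 log units; beyond the scatter), is a modest one. Compound 4 `Nc1n[nH]c2cc(-c3ccc(=O)n(Cc4cccc(F)c4)c3)ccc12` is not yet measured; it differs from compound 3 by fluoro in place of acetamido on an aromatic carbon. Fluoro brings none of the hydrogen-bond donor and acceptor that acetamido carried, and in that respect compound 4 resembles compound 1, with its 32 nM. The expected step is therefore a 3.1-fold higher number from compound 3 to compound 4 (0.49 log units; beyond the scatter), most of the modest gain from compound 1 being given back. Compound 4 is expected to show about 25 nM in this assay, within 10 nM to 70 nM.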

Compound 4, half-maximal inhibitory concentration: 5 nM
Compound 4: the middle estimate sits 5.0-fold (0.70 log units) above what was measured; the measured number lies below the stated range.
By their numbers in this assay, from the lowest: compounds 4 and 3 (each within the scatter of the next); then compound 1. At a limit, above all of these: compound 2.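

In this assay, the hydrogen-bond donor and acceptor of acetamido prove unnecessary at this place, meta to a large group, with fluoro and acetamido reading alike in a 1.6-fold lower number from compound 3 to compound 4 (0.20 log units; within the scatter). The gain over hydrogen survives with a single fluorine, as shown by a 6.4-fold lower number from compound 1 to compound 4 (0.81 log units; beyond the scatter). Nothing measured here explains why fluoro matches acetamido.

On these data alone, whether chloro, methyl or a nitrile at this place would read like fluoro stays open. So does the effect of fluoro on the other carbons of that ring.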